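Moving the Pyrazole Attachment Point in a Urea Series

The source may hold more compounds than are shown below. What is called first, only, known or untested is meant among the compounds shown, and "the series" means these compounds.

Compound 1 `Cc1cc(C)c(NC(=O)N(Cc2ccc(-c3nnc(C)o3)cc2)C2CCCCCC2)c(C)c1`, compound 2 `Cc1cc(C)c(NC(=O)N(Cc2ccc(-n3cccn3)cc2)C2CCCCCC2)c(C)c1` and compound 3 `Cc1cc(C)c(NC(=O)N(Cc2ccc(-c3cc[nH]n3)cc2)C2CCCCCC2)c(C)c1` share one core and differ only in the small ring hung on the six-membered aromatic ring. In a functional assay on a cell-free system (plasma) with sterol O-acyltransferase, Soat (Rattus norvegicus) as the target (a lower number here means that less compound is needed, a higher number that more compound is needed for the effect), compound 1 gives > 0.32 mg/kg, which is a limit of the assay rather than a number. Compound 2 gives > 1 mg/kg in this assay, again a limit. Compound 3 gives > 1 mg/kg, also a limit. Compound 3 therefore stands where two of the three values shown sit, at the limit of > 1 mg/kg in this assay, at which 2 of the 3 values shown sit, while the remaining value sits at the limit of > 0.32 mg/kg in this assay, at which 1 of the 3 values shown sits. The steps among these three, a step that the two limits leave unreadable from compound 1 to compound 2, a step that the two limits leave unreadable from compound 1 to compound 3 and a step that the two limits leave unreadable from compound 2 to compound 3, cannot be read, since both ends of each are limits.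

Compound 4 `Cc1cc(C)c(NC(=O)N(Cc2ccc(-c3cn[nH]c3)cc2)C2CCCCCC2)c(C)c1` has not yet been measured. It differs from compound 3 by 1H-pyrazol-4-yl in place of 1H-pyrazol-3-yl on an aromatic carbon. Among the measured compounds shown here, no measured step bears on this change with a readable size; the three known steps show only that every value sits at a limit. The step from compound 3 to compound 4 is expected to be a step that the limit leaves unreadable from compound 3 to compound 4, that is, nothing beyond the scatter. Compound 4 is estimated to give 3 mg/kg in this assay, with a range from 1 mg/kg to 30 mg/kg, most likely reported once more as a limit.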

Compound 4, dose for half-maximal effect: > 1 mg/kg
Compound 4 ended at the assay's limit (the forecaster's own chance of this, stated with the estimate: 80%); the middle value is on the limit's open side.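

In this assay compound 4 gives > 1 mg/kg, which is a limit. Each of its steps to compound 1, compound 2 and compound 3 joins two limits and cannot be read. The compounds shown leave open how much of any of these four compounds is needed for the effect, and whether moving the pyrazole attachment point changes that amount at all.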